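A Side Chain Swap Tracked Through Lipophilicity

A few compounds are considered here, and "the series" means these few. Any claim that something is new, unique, unknown or untested is made for them only; others in the source may bear on it.

Of the compounds shown here, three sharing one core have been measured in a physicochemical assay for lipophilicity, at pH 7.4; a lower number here means a more polar compound, a higher number a more lipophilic compound. Compound 1 `Cc1cc(COc2cccc(C#N)c2)nc(-c2ccccn2)n1` gives 2.7, compound 2 `Cc1cc(COc2ccc(F)c(F)c2)nc(-c2ccccn2)n1` gives 3.2, and compound 3 `CC1(C)CN(c2cc(COc3ccc(F)c(F)c3F)nc(-c3ccccn3)n2)C1` gives 4.3. Compound 3 stands highest of the three numbers, above compound 2 and further still above compound 1, both gaps lying beyond the scatter of the method. Compound 4 `N#CCC1(COc2cc(COc3ccc(F)c(F)c3F)nc(-c3ccccn3)n2)COC1` has not yet been measured in this assay. It differs from compound 3 in one place ((3-(cyanomethyl)oxetan-3-yl)methoxy in place of 3,3-dimethylazetidin-1-yl on an aromatic carbon). Within the data shown here, no measured pair isolates this change, so the expectation rests on the structures alone. In this assay a fall beyond the scatter is expected, a number 1.30 log units lower from compound 3 to compound 4 (beyond the scatter). Compound 4 is accordingly estimated at 3, within a range from 2.4 to 3.6.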

Compound 4, distribution coefficient: 3.3
Compound 4: middle estimate off by 0.30 log units, on the low side; the range from low to high includes it.
By their numbers in this assay, from the lowest: compound 1; then compounds 2 and 4 (each within the scatter of the next); then compound 3.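

In this assay, (3-(cyanomethyl)oxetan-3-yl)methoxy in place of 3,3-dimethylazetidin-1-yl on an aromatic carbon gives a number 1.00 log units lower from compound 3 to compound 4 (beyond the scatter), the first single-place change measured in this series. It shows that the number responds to the group at this position, even though both groups carry a four-membered non-aromatic ring with 1 hetero atom. Nothing measured here gives a reason for the step. The compounds shown leave open which part of the entering group accounts for the step, and how a plain methoxy group or a morpholine would read at this position.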